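A few compounds are considered here, and "the series" means these few. Any claim that something is new, unique, unknown or untested is made for them only; others in the source may bear on it.

Series notes. For the measured compounds named here, compound 1 `O=c1cc(/C=N\c2ccccc2O)c2c(OCc3ccccc3)cc(OCc3ccccc3)cc2o1` is the only member with a numbered result in a functional assay, read by spectrophotometry, with a stated time of 1 h; on this read-out higher numbers stand for weaker inhibition and lower numbers for stronger inhibition: compound 1 gives 348000 nM. Compound 2 `O=c1cc(/C=N\O)c2ccc(OCc3ccccc3)cc2o1` reaches only a limit of the assay in this assay, reported as > 2000000 nM. Compound 3 `O=c1cc(-c2nc3ccccc3[nH]2)c2ccc(OCc3ccccc3)cc2o1` is recorded in this assay as "not active" (no number reported), with no number attached. Going by the values given here, no step between measured compounds is available, so no measured size of change can be quoted for a single alteration. Compound 4 `O=c1cc(/C=N\c2ccc(O)cc2)c2c(OCc3ccccc3)cc(OCc3ccccc3)cc2o1` differs from compound 1 by 4-hydroxyphenyl in place of 2-hydroxyphenyl on a double-bonded nitrogen, in words 4-hydroxyphenyl in place of 2-hydroxyphenyl on a double-bonded nitrogen. Among the compounds with values here, with the same atoms joined differently and no comparable step to draw on, a change of no more than the usual scatter is expected in either direction in this assay. The estimated step is a 1.0-fold higher number from compound 1 to compound 4 (0.00 log units; within the scatter). Compound 4 is therefore expected to give about 350000 nM, between 120000 nM and 1000000 nM.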

Compound 4, half-maximal inhibitory concentration: 107000 nM
For compound 4 the middle estimate is 3.3-fold (0.51 log units) above the measured one, outside the stated range (below it).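

In this assay, for the compounds shown here, 4-hydroxyphenyl in place of 2-hydroxyphenyl on a double-bonded nitrogen gives a 3.3-fold lower number from compound 1 to compound 4 (0.51 log units; beyond the scatter), the first measured size of change. Rearranging the same atoms at this one place is thus enough to shift the number beyond the scatter, towards stronger inhibition. No measurement shown bears on why this step arises.

As far as these compounds go, it remains open whether the hydroxyl itself is needed. A plain phenyl, 4-aminophenyl or 4-carboxyphenyl group on this nitrogen would test that.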